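Taking the methoxy group off compound 2

The compounds below may be only part of what the source reports. "The series", "measured", "known", "first", "only" and "open" are said of these compounds alone.

In a functional assay on NSCLC cells (Homo sapiens) for cytotoxicity, read by sulforhodamine B assay, with a stated time of 48 h (a higher number here means that more compound is tolerated, a lower number that less compound is tolerated), compound 1 `COc1cc2c(cc1C)NC(=O)/C2=C/c1c(OC)nc2sc(C)cn12` gives 98000 nM and compound 2 `COc1ccc2c(c1)/C(=C\c1c(OC)nc3sc(C)cn13)C(=O)N2` gives 88900 nM within the scatter of compound 1, so the two stand level. Still unmeasured, compound 3 `COc1nc2sc(C)cn2c1/C=C1/C(=O)Nc2ccccc21` differs from compound 2 by hydrogen in place of methoxy on an aromatic carbon with hydrogen in place of methoxy on an aromatic carbon. Within the data shown here, only one measured step bears on this change. That step puts hydrogen in place of methyl on an aromatic carbon, so it concerns a different group and is a loose guide. Among the measured compounds shown here, no measured step removes a methoxy group. With only a 1.1-fold lower number from compound 1 to compound 2 (0.04 log units; within the scatter) to go on, a step beyond the scatter is not expected in this assay and no direction is favoured. The expected change is a 1.0-fold higher number from compound 2 to compound 3 (0.01 log units; within the scatter) by this estimate. For compound 3 the estimated value is 90000 nM with an expected range from 40000 nM to 200000 nM on present data.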

Compound 3, concentration lethal to 50% of the cells: 99000 nM
Compound 3: the middle estimate sits 1.1-fold (0.04 log units) below what was measured, within the range that was stated.
By their numbers in this assay, from the lowest: compounds 2, 1 and 3 (each within the scatter of the next).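

In this assay, taking the methoxy group off an aromatic carbon of the six-membered aromatic ring of carbon only gives a 1.1-fold higher number from compound 2 to compound 3 (0.05 log units; within the scatter), so an oxygen-linked group at this position now has a direct reading, which the earlier methyl step could not supply. Read beside a 1.1-fold lower number from compound 1 to compound 2 (0.04 log units; within the scatter), this makes two single-place steps on this ring, and neither leaves the scatter; compound 3 carries neither the methyl nor the methoxy group and still stands level with compound 2. No supporting data bear on this result.

Open, going by these compounds, is whether a group of another kind at this position, such as an amine, a carboxylic acid or a longer alkoxy chain, would move the number beyond the scatter. Also open, on these data alone, is whether the methoxy and methyl groups on the other part of the shared core matter more in this assay.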